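The compounds below may be only part of what the source reports. "The series", "measured", "known", "first", "only" and "open" are said of these compounds alone.

Working notes on the series in a functional assay on SW-620 cells (Homo sapiens) for inhibition, read by MTT assay, with a stated time of 4 days; a higher number here means a weaker inhibitor, a lower number a stronger inhibitor.

Compound 1 `CCOC(=O)NC(c1ccccc1)c1ccc(Cl)cc1` gives only a limit in this assay, > 100000 nM, and is not a number. Compound 2 `COc1ccc(C(=NNC(=O)NNC(=O)NCCCC(C)Nc2cc(OC)cc3cccnc23)c2ccc(OC)cc2)cc1` likewise gives only a limit in this assay, >= 100000 nM. Among the compounds with values here, compound 3 `COc1cc(NC(C)CCCNC(=O)Nc2ccc(Cl)c(C(F)(F)F)c2)c2ncccc2c1` is the one compound of the three with a measured value; in this assay compound 3 gives 23000 nM. Compound 3 therefore stands as the only point on the scale, while the other two values shown are limits, one sitting at the limit of > 100000 nM in this assay, at which 1 of the 3 values shown sits, and one at the limit of >= 100000 nM in this assay, at which 1 of the 3 values shown sits.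

Compound 4 `COc1cc(NC(C)CCCNC(=O)NNC(=O)NCCO)c2ncccc2c1` has not yet been measured in this assay. It keeps the core of compound 3 and differs in one place: ((2-hydroxyethyl)carbamoyl)amino in place of 4-chloro-3-(trifluoromethyl)phenyl on an amide-type nitrogen. Compound 2 also carries a carbamoyl-hydrazide chain and stands at a limit. Within the data shown here, no measured pair differs in exactly this way, so the size of the step rests on expectation only. The step from compound 3 to compound 4 is expected to run in the weaker direction and to exceed the usual scatter, estimated as a 3.5-fold higher number from compound 3 to compound 4 (0.54 log units; beyond the scatter). For compound 4 the estimated value in this assay is 80000 nM, with a range from 20000 nM to 300000 nM, and a sizeable chance that only a limit is returned.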

Compound 4, half-maximal inhibitory concentration: > 100000 nM
Compound 4: only a limit was reported; the forecaster's own chance of this, stated with the estimate: 55%; middle value at least 1.2-fold (0.09 log units) away from the limit.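

Within the data shown here, on the amide-type nitrogen whose other neighbour is the carbonyl carbon, replacing 4-chloro-3-(trifluoromethyl)phenyl with ((2-hydroxyethyl)carbamoyl)amino gives the first step that can be read in this assay, an at least 4.3-fold higher number from compound 3 to compound 4 (0.63 log units; beyond the scatter). Among these compounds, compound 4 returns only a limit, so this step gives a minimum size with no upper end: the limit of > 100000 nM in this assay, at which 2 of the 4 values shown sit. The earlier compounds offered no pair differing in one place, and this pair now shows that the number in this assay responds to the group on this nitrogen, with an aromatic ring of carbon leaving and a chain with no ring entering in the same change.

The compounds shown leave open which part of the change carries the step: the loss of the ring, the loss of the chloro and trifluoromethyl groups, or the arrival of the ((2-hydroxyethyl)carbamoyl)amino chain. An unsubstituted phenyl or a cyclohexyl group on the same nitrogen would begin to separate these, and would show whether any group other than 4-chloro-3-(trifluoromethyl)phenyl keeps a measurable value.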